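A few compounds are considered here, and "the series" means these few. Any claim that something is new, unique, unknown or untested is made for them only; others in the source may bear on it.

In a toxicity assay on GES1 cells (Homo sapiens) for inhibition, read by MTT assay, with a stated time of 72 h (on this read-out higher numbers stand for weaker inhibition and lower numbers for stronger inhibition), compound 1 `Cc1cc(N2CC[C@@H](C)[C@@H](N(C)c3ncnc4[nH]ccc34)C2)n2nc(SCc3ccc(Cl)cc3)nc2n1` gives > 100000 nM, which is a limit. Compound 2 `Cc1cc(N2CC[C@@H](C)[C@@H](N(C)c3ncnc4[nH]ccc34)C2)n2nc(SCc3csc4ccc(Cl)cc34)nc2n1` gives > 100000 nM, likewise a limit, and that is all that is known of where it stands. Both compounds rest at the limit of > 100000 nM in this assay, at which 2 of the 2 values shown sit. Compound 3 `Cc1cc(N2CC[C@@H](C)[C@@H](N(C)c3ncnc4[nH]ccc34)C2)n2nc(SCc3ccc(F)cc3)nc2n1` follows from compound 2 by 4-fluorophenyl in place of 5-chloro-1-benzothiophen-3-yl on a saturated chain carbon bound to a sulfur, with 4-fluorophenyl in place of 5-chloro-1-benzothiophen-3-yl on a saturated chain carbon bound to a sulfur. Within the data shown here, the only measured step at this place is a step that the two limits leave unreadable from compound 1 to compound 2, so it offers no size to carry over, and no change beyond the scatter is expected. The expected move is a number no higher from compound 2 to compound 3 (the limit leaves the size open). For compound 3 the estimated half-maximal inhibitory concentration is 100000 nM, with an expected range of 50000 nM to 200000 nM.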

Compound 3, half-maximal inhibitory concentration: 12300 nM
Compound 3: the middle estimate sits 8.1-fold (0.91 log units) above what was measured, outside the stated range (below it).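

In this assay, this position proves able to shift the read-out, with an at least 8.1-fold lower number from compound 2 to compound 3 (0.91 log units; beyond the scatter). Fluoro in place of chloro on an aromatic carbon is enough by itself, giving an at least 8.1-fold lower number from compound 1 to compound 3 (0.91 log units; beyond the scatter). Both sizes are only minimums, since the starting compounds stand at a limit: the limit of > 100000 nM in this assay, at which 2 of the 3 values shown sit.

As far as these compounds go, the true size of either step remains open. So does how a bromo or methyl group in place of fluoro on that aromatic carbon would read here.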